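A few compounds are considered here, and "the series" means these few. Any claim that something is new, unique, unknown or untested is made for them only; others in the source may bear on it.

In a toxicity assay on L02 cells (Homo sapiens) for cytotoxicity, read by MTT assay, with a stated time of 72 h (a higher number here means a weaker inhibitor, a lower number a stronger inhibitor), compound 1 `C=CC(=O)N1CCC(Oc2nc(Nc3ccc(N4CCN(C)CC4)cc3OC)nc3[nH]ccc23)CC1` gives 18000 nM, compound 2 `C=CC(=O)N1CCC(Oc2nc(Nc3cnn(C)c3)nc3[nH]ccc23)CC1` gives 10200 nM and compound 3 `C=CC(=O)N1CCC(Oc2nc(Nc3ccc(N4CCN(C)CC4)cc3OC)nc3ccsc23)CC1` gives 1970 nM, the lowest number of the three. Compound 4 `C=CC(=O)N1CCC(Oc2nc(Nc3ccc(N4CCN(C)CC4)cc3)nc3ccsc23)CC1` keeps the structure of compound 3 apart from one change: hydrogen in place of methoxy on an aromatic carbon. That is hydrogen in place of methoxy on an aromatic carbon. For the measured compounds named here, no measured pair isolates this change, so the data give no direct size for it. In this assay, no step beyond the scatter is expected, with the number staying near that of compound 3 at 1970 nM. The estimated step is a 1.3-fold higher number from compound 3 to compound 4 (0.10 log units; within the scatter). For compound 4, the expected value is 2500 nM, with an estimated range of 900 nM to 7000 nM.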

Compound 4, half-maximal inhibitory concentration: 8450 nM
For compound 4 the middle estimate is 3.4-fold (0.53 log units) below the measured one; measured number outside the range, above it.
By their numbers in this assay, from the lowest: compound 3; then compounds 4, 2 and 1 (each within the scatter of the next, the first and the last beyond it).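

In this assay, for the compounds shown here, hydrogen in place of methoxy on an aromatic carbon, ortho to a large group, gives a 4.3-fold higher number from compound 3 to compound 4 (0.63 log units; beyond the scatter) and provides the first single-place comparison. At this position, methoxy therefore goes with the lower number in this pair. Nothing available accounts for the size of this step.

As far as these compounds go, whether this step is specific to methoxy remains open, as fluorine, ethoxy or an amine on the same aromatic carbon would test that. Also open, from the compounds shown here alone, is whether the same change on the core of compound 1 gives a similar step.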